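This account rests on a few compounds, and the source may have more. Where it says the series, first, only, none or still open, it means among the compounds named here.

Compound 2 `CCN1CCN(c2cc(C)c3cc(NC(=O)c4cccnc4)ccc3n2)CC1` gives 10600 nM in a functional assay on SK-BR-3 cells (Homo sapiens) for antiproliferative activity, read by MTT assay, with a stated time of 72 h (a higher number here means a weaker inhibitor, a lower number a stronger inhibitor), the highest of the two numbers reported; nearest is compound 3 `Cc1cc(NCCN2CCCCC2)nc2ccc(NC(=O)c3ccc(Cl)c(Cl)c3)cc12` at 1800 nM. Compound 1 `Cc1cc(N(C)C)nc2ccc(NC(=O)c3ccc(Cl)c(Cl)c3)cc12` reaches only the assay limit, > 50000 nM. Within the data shown here, the single step measured, an at least 27-fold lower number from compound 1 to compound 3 (1.44 log units; beyond the scatter), concerns the amine side of the shared core and bears against (the limit of > 50000 nM in this assay, at which 1 of the 3 values shown sits). Compound 4 `CCN1CCN(c2cc(C)c3cc(NC(=O)c4ccc(Br)cc4)ccc3n2)CC1` differs from compound 2 only at the amide: 4-bromophenyl in place of pyridin-3-yl on a carbonyl carbon. Among the measured compounds shown here, no measured step touches this carbonyl substituent, so no precedent sets the direction; the amine side is held fixed. A step of modest size in either direction is expected, a 1.8-fold lower number from compound 2 to compound 4 (0.25 log units; within the scatter), and compound 4 is estimated at 6000 nM, between 1500 nM and 25000 nM.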

Compound 4, half-maximal inhibitory concentration: 6310 nM
Compound 4: the middle estimate sits 1.1-fold (0.02 log units) below what was measured, and the stated range covers the measured number.
By their numbers in this assay, from the lowest: compound 3; then compounds 4 and 2 (each within the scatter of the next). At a limit, above all of these: compound 1.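

Among these compounds, the first measured change at this carbonyl carbon gives a 1.7-fold lower number from compound 2 to compound 4 (0.23 log units; within the scatter) in this assay, so with the amine side held fixed, pyridin-3-yl and 4-bromophenyl are not told apart. Loss of the ring nitrogen and entry of bromine come as one change, and their separate contributions cannot be read. No measurement shown bears on a cause for this step.

Open, going by these compounds, is whether a non-aromatic group on the carbonyl, such as cyclohexyl, or a phenyl ring carrying a carboxylic acid or a morpholine, would move the number beyond the scatter.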